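This account rests on a few compounds, and the source may have more. Where it says the series, first, only, none or still open, it means among the compounds named here.

Among the measured compounds shown here, compound 3 `O=C(O)CNC(=O)CN(c1nc(Cl)nc2[nH]cnc12)C1CC1` gives 9.08% in a functional assay on the whole organism (Tail, strain ICR) with Mus musculus as the target, in the tail flick test, with a stated time of 150 min, at a dose of 25 umol/kg by the oral route (a higher number here means a stronger effect of the compound at the dose given, a lower number a weaker effect), the lowest of the three numbers so far: compound 1 `O=C(CN(c1nc(Cl)nc2[nH]cnc12)C1CC1)NCC(=O)OCc1ccccc1` gives 18%, which lies within the scatter of it, while compound 2 `O=C(CN(c1nc(Cl)nc2[nH]cnc12)C1CC1)N[C@@H](CCC(=O)OCc1ccccc1)C(=O)OCc1ccccc1` gives 44.5%, beyond it. Compound 4 `C[C@H](NC(=O)CN(c1nc(Cl)nc2[nH]cnc12)C1CC1)C(=O)O` differs from compound 3 by methyl in place of hydrogen on a saturated chain carbon bound to an amide-type nitrogen and a carbonyl carbon. For the measured compounds named here, only one measured step touches that place: a number 26.5 percentage points higher from compound 1 to compound 2 (beyond the scatter), where the entering group was 2-(benzyloxycarbonyl)ethyl, not the single-carbon methyl entering here. The other step, a number 8.9 percentage points lower from compound 1 to compound 3 (within the scatter), concerns a different place and offers no guide. For compound 4 the expected step is a number 4.9 percentage points higher from compound 3 to compound 4 (within the scatter), a small step that stays within the scatter. Compound 4 is therefore estimated at 14%, and its expected range runs from 3% to 30%.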

Compound 4, a percentage reported as activity, at one dose (the size of the read-out at that dose, not a potency): 14.7%
Estimate against measurement, compound 4: 0.7 percentage points below, within the range that was stated.
By their numbers in this assay, from the lowest: compounds 3, 4 and 1 (each within the scatter of the next); then compound 2.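

In this assay, methyl on this saturated chain carbon gives a number 5.6 percentage points higher from compound 3 to compound 4 (within the scatter), so with the carboxylic acid left free, this single added carbon does not separate the two compounds. Among the compounds shown here, the only earlier change at this place, in compound 2, brought in the far larger 2-(benzyloxycarbonyl)ethyl on a benzyl ester, so this is the first reading of the place on a free acid. Nothing measured here offers an explanation. Still open, going by these compounds, is whether a longer chain, or a chain ending in an amine, at this carbon would move a free acid beyond the scatter.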